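Ester-to-amide exchange at the carbonyl of the diene chain

The source may report more compounds than this note shows. Statements on the series, on what has been measured and on what is new or still open speak of the compounds shown alone.

Three esters of the same diene acid have been measured in a physicochemical assay for lipophilicity; a lower number here means a more polar compound, a higher number a more lipophilic compound. Compound 1 `CCCOC(=O)/C=C(C)/C=C/CC(C)CCCC(C)(C)OC` gives 6.08, compound 2 `CCCCOC(=O)/C=C(C)/C=C/CC(C)CCCC(C)(C)OC` gives 6.62, and compound 3 `COC(C)(C)CCCC(C)C/C=C/C(C)=C/C(=O)OC1CC1` gives 5.71. Compound 3 stands lowest of the three; the step of a number 0.37 log units lower from compound 1 to compound 3 (beyond the scatter) follows a cyclopropyl in place of propyl on an oxygen next to a carbonyl group, and the step of a number 0.91 log units lower from compound 2 to compound 3 (beyond the scatter) follows a cyclopropyl in place of butyl on the same oxygen. The step of a number 0.54 log units higher from compound 1 to compound 2 (beyond the scatter) follows a methyl in place of hydrogen on a saturated chain carbon, three bonds along the chain from an oxygen next to a carbonyl group.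

Compound 4 `COC(C)(C)CCCC(C)C/C=C/C(C)=C/C(=O)N(C)C` differs from compound 3 as follows: dimethylamino in place of cyclopropyloxy on a carbonyl carbon. Cut one bond further out, the difference reads cyclopropyloxycarbonyl to dimethylcarbamoyl. Going by the values given here, none of the measured steps touches the carbonyl carbon itself; all three only vary the group on the oxygen, so none bears directly on this exchange, and the size of the step is not fixed by the series. The expectation for this assay is nevertheless a step downward beyond the scatter, of about a number 1.21 log units lower from compound 3 to compound 4 (beyond the scatter). On that basis compound 4 is estimated at 4.5, with a range from 3.8 to 5.2.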

Compound 4, partition coefficient: 3.74
The estimate for compound 4 lay 0.76 log units above the measured number, outside the stated range (below it).
By their numbers in this assay, from the lowest: compound 4; then compound 3; then compound 1; then compound 2.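

In this assay, replacing the group on the oxygen with dimethylamino on the carbonyl carbon gives the largest steps in the series, whichever ester serves as the reference: cyclopropyloxy (a number 1.97 log units lower from compound 3 to compound 4 (beyond the scatter)), propoxy (a number 2.34 log units lower from compound 1 to compound 4 (beyond the scatter)) and butoxy (a number 2.88 log units lower from compound 2 to compound 4 (beyond the scatter)). The steps among the esters were all modest and these are all large, so within these four compounds the exchange at the carbonyl carbon outweighs the variation of the group on the oxygen, and compound 4 stands lowest. No measurement at hand speaks to what lies behind the size of these steps.

Dimethylamino is the only amine group on this carbonyl carbon among the compounds shown, so it remains open whether the large steps hold for amides in general or are particular to this one. Methylamino, pyrrolidinyl or a longer dialkylamino chain on the same carbonyl carbon, or the free carboxylic acid, would show how far the number moves with the group that replaces the ester oxygen.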